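The compounds below may be only part of what the source reports. "The series", "measured", "known", "first", "only" and "open" are said of these compounds alone.

Compound 1 `CNC(=N)Nc1nc(-c2ccc(OC)cc2)c(-c2ccc(OC)cc2)s1` gives 1.2 uM in a functional assay (aorta) with Rattus norvegicus as the target (a higher number here means that more compound is needed for the effect, a lower number that less compound is needed), the lowest of the two numbers shown; nearest stands compound 3 `COc1ccc(-c2nc(/N=C(\N)N3CCOCC3)sc2-c2ccc(OC)cc2)cc1`, which gives 66 uM. Compound 2 `COc1ccc(-c2nc(/N=C(\N)NC3CCCCC3)sc2-c2ccc(OC)cc2)cc1` reaches only a limit of this assay, > 100 uM (the limit of > 100 uM in this assay, at which 1 of the 3 values shown sits). Both measured changes at the same aromatic carbon raise the number: an at least 83-fold higher number from compound 1 to compound 2 (1.92 log units; beyond the scatter) and a 55-fold higher number from compound 1 to compound 3 (1.74 log units; beyond the scatter). Compound 4 `CNC(=O)NCc1nc(-c2ccc(OC)cc2)c(-c2ccc(OC)cc2)s1` differs from compound 1 in this way: a group of 6 heavy atoms (3 carbon, 2 nitrogen, 1 oxygen; no ring) in place of a group of 5 heavy atoms (2 carbon, 3 nitrogen; no ring), on an aromatic carbon. Neither measured step brings in a group without a ring, so both bear on this change only loosely; a rise is nonetheless expected, smaller than those two, an 8.3-fold higher number from compound 1 to compound 4 (0.92 log units; beyond the scatter). For compound 4 the estimate in this assay is 10 uM, with a range from 2 uM to 60 uM.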

Compound 4, concentration for half-maximal effect: 15 uM
Compound 4: the middle estimate sits 1.5-fold (0.18 log units) below what was measured; the range from low to high includes it.
By their numbers in this assay, from the lowest: compound 1; then compound 4; then compound 3. At a limit, above all of these: compound 2.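

At this aromatic carbon, the ring-free ((methylcarbamoyl)amino)methyl group stays closer to compound 1 than either ring-bearing group, yet the change still raises the number: a 13-fold higher number from compound 1 to compound 4 (1.10 log units; beyond the scatter). Against the group carrying morpholin-4-yl, the number falls: a 4.4-fold lower number from compound 3 to compound 4 (0.64 log units; beyond the scatter). Compound 2 is a limit and not a number, and an at least 6.6-fold lower number from compound 2 to compound 4 (0.82 log units; beyond the scatter) is therefore only a floor.

The carbonyl and the methyl link enter together, and the compounds shown do not separate them. From the compounds shown here alone, what a plain amine or a longer chain would give at this carbon remains open.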